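Sulfonyl substituent swap in a weakly antiproliferative quinolone series

A few compounds are considered here, and "the series" means these few. Any claim that something is new, unique, unknown or untested is made for them only; others in the source may bear on it.

Measured compounds:
- compound 1, `COc1ccc(-c2c(Cl)c(=O)c3c(OC)cc(OC)cc3n2S(=O)(=O)c2ccc(OC)cc2)cc1`: 17900 nM in a functional assay on SUP-B15 cells (Homo sapiens) for antiproliferative activity, with a stated time of 72 h; a higher number here means that more compound is needed for the effect, a lower number that less compound is needed
- compound 2, `COc1ccc(-c2cc(=O)c3c(OC)cc(OC)cc3n2S(=O)(=O)c2ccc([N+](=O)[O-])cc2)cc1`: 17100 nM in this assay

Both measured compounds carry the same core and differ at the group on the sulfonyl sulfur. In this assay compound 2 gives 17100 nM, and compound 1 gives 17900 nM; these two numbers lie within the scatter of each other, so neither compound can be put ahead of the other. The series as a whole sits at high concentrations in this assay.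

Compound 3, `COc1ccc(-c2cc(=O)c3c(OC)cc(OC)cc3n2S(=O)(=O)Cc2ccccc2)cc1`, is not yet measured. It differs from compound 2 at the sulfonyl sulfur: benzyl in place of 4-nitrophenyl on a sulfonyl sulfur. For the measured compounds named here, no measured pair in this set shows what such a change does, so the expectation rests on the two measured compounds alone, which show that the group on the sulfonyl sulfur has so far made no difference beyond the scatter.

Compound 3 is therefore expected to give roughly the same weak activity, with a step of a 1.2-fold higher number from compound 2 to compound 3 (0.07 log units; within the scatter) that may well be none beyond the scatter. The estimate for compound 3 in this assay is 20000 nM, with a range from 7000 nM to 60000 nM.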

Compound 3, half-maximal effective concentration: > 34400 nM
Compound 3: only a limit was reported; the forecaster's own chance of this, stated with the estimate: 25%; middle value at least 1.7-fold (0.23 log units) from the limit.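

Benzyl in place of 4-nitrophenyl on a sulfonyl sulfur is the first change at a single place that can be read in this series, and in this assay compound 3 is reported only as a limit, > 34400 nM. As far as these compounds go, the step is an at least 2.0-fold higher number from compound 2 to compound 3 (0.30 log units; that floor lies within the scatter), so this swap gives no sign of a lower number, while its floor alone does not separate the two compounds and the true size of the change remains unknown. The reading of this pair therefore ends at a limit rather than at a measured value for compound 3: the limit of > 34400 nM in this assay, at which 1 of the 3 values shown sits.

From the compounds shown here alone, it remains open how far the number for compound 3 lies from that of compound 2, and so whether 4-nitrophenyl and benzyl truly differ in this assay. Going by these compounds, it also remains open whether a different group on the sulfonyl sulfur, such as a simple methyl, an amine or a longer chain ending in a carboxylic acid, would bring the number down from the high concentrations seen so far.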